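Replacing the phenylsulfanyl end of compound 3

The compounds below may be only part of what the source reports. "The series", "measured", "known", "first", "only" and "open" are said of these compounds alone.

In a functional assay on ileum (Cavia porcellus) for antagonist activity, with a stated time of 30 s (a lower number here means a stronger inhibitor, a higher number a weaker inhibitor), compound 1 `O=C(O)c1cc(=O)c2cc(CCCc3ccccc3)ccc2o1` gives 3 ug/mL, compound 2 `O=C(O)c1cc(=O)c2ccc(OCCCOc3ccccc3)cc2o1` gives 1.4 ug/mL, and compound 3 `O=C(O)c1cc(=O)c2ccc(OCCCCCSc3ccccc3)cc2o1` gives 0.4 ug/mL. Compound 3 therefore holds the lowest number of the three, and its gaps to both others lie beyond the scatter. The next structure, compound 4 `CC(=O)c1ccc(OCCCCCOc2ccc3c(=O)cc(C(=O)O)oc3c2)cc1`, keeps the shared core and alters the far end of the chain: 4-acetylphenoxy in place of phenylsulfanyl on a saturated chain carbon, five bonds along the chain from an oxygen on an aromatic ring.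

Going by the values given here, only one measured step bears on this change. That step is a 3.5-fold lower number from compound 2 to compound 3 (0.54 log units; beyond the scatter), a modest move in which 2-(phenylsulfanyl)ethyl took the place of phenoxy. Compound 4 again ends in a phenoxy group, as compound 2 does, but this one carries an acetyl group. Among the compounds with values here, the data cannot show how much of the measured step belongs to the sulfur, and no measured compound carries an acetyl group. A partial return toward the higher number of compound 2, which stands at 1.4 ug/mL, is therefore expected, though with wide uncertainty. The expected change is a 1.8-fold higher number from compound 3 to compound 4 (0.24 log units; within the scatter). For compound 4 the estimated value is 0.7 ug/mL, with an expected range from 0.25 ug/mL to 2 ug/mL.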

Compound 4, half-maximal inhibitory concentration: 3.5 ug/mL
The estimate for compound 4 lay 5.0-fold (0.70 log units) below the measured number; the measured number lies above the stated range.
By their numbers in this assay, from the lowest: compound 3; then compound 2; then compounds 1 and 4 (each within the scatter of the next).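

The change at the far end of the chain proved far from neutral in this assay: the new end brought an 8.8-fold higher number from compound 3 to compound 4 (0.94 log units; beyond the scatter), which took compound 4 out of the low range held by compound 3 and level, within the scatter, with compound 1. Both ends hold one six-membered aromatic ring of carbon only, so that ring alone does not secure the low number of compound 3, and the earlier step, a 3.5-fold lower number from compound 2 to compound 3 (0.54 log units; beyond the scatter), could not have shown this. No evidence at hand explains the rise.

The compounds shown leave open which part of the swap carries the step, since the sulfur link gives way to an oxygen link and the acetyl group enters in one move, with the end growing from 7 to 10 heavy atoms. A plain phenoxy end on this same chain, or a 4-acetylphenylsulfanyl end, would separate those parts, and an amine or a carboxylic acid in the acetyl's place would show whether the loss follows that particular group.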